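This account rests on a few compounds, and the source may have more. Where it says the series, first, only, none or still open, it means among the compounds named here.

In a functional assay on HUVEC cells (Homo sapiens) for inhibition, with a stated time of 4 days (a higher number here means a weaker inhibitor, a lower number a stronger inhibitor), the measured compounds read:
- compound 1 `COc1ccc(C(C)=O)cc1COc1cccc(C)c1` at 2800 nM
- compound 2 `Cc1cc(OCc2cccc(C#N)c2)ccc1Cl` at 11000 nM
- compound 3 `COc1ccc(C(N)=O)cc1/C=C/c1ccc(C(C)(C)C)cc1` at 370 nM

Compound 3 has the lowest number of the three, and its gaps to compound 1 and compound 2 both lie beyond the scatter. Compound 4 `COc1ccc(C(N)=O)cc1/C=C/c1ccc(C#N)cc1` has cyano in place of tert-butyl on an aromatic carbon, para to a large group (cyano in place of tert-butyl on an aromatic carbon). Among the measured compounds shown here, no measured pair isolates this change. For the measured compounds named here, compound 2, the only measured compound with cyano, stands at 11000 nM but also differs from compound 3 elsewhere. On that slim evidence, a rise beyond the scatter in this assay, towards weaker inhibition, is expected, the estimated step being (a 4.1-fold higher number from compound 3 to compound 4 (0.61 log units; beyond the scatter)) on this reading. Compound 4 is estimated at 1500 nM with an expected range from 400 nM to 6000 nM in this series.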

Compound 4, half-maximal inhibitory concentration: 3100 nM
Compound 4: middle estimate off by 2.1-fold (0.32 log units), on the low side; the range from low to high includes it.
By their numbers in this assay, from the lowest: compound 3; then compounds 1 and 4 (each within the scatter of the next); then compound 2.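

In this assay, among the compounds shown here, cyano in place of tert-butyl on an aromatic carbon, para to a large group, gives an 8.4-fold higher number from compound 3 to compound 4 (0.92 log units; beyond the scatter), the first reading of this change with the rest of the structure held constant. The position is therefore not indifferent to its substituent, and tert-butyl gives the lower number of the two groups read there. No available evidence explains the step.

Only these two groups are compared at this position. Going by these compounds, whether an amine, a carboxylic acid or a longer alkyl chain there would read nearer compound 3 or compound 4 remains open.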